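Piperazine substituent change on a melanin-concentrating hormone receptor ligand

The source may hold more compounds than are shown below. What is called first, only, known or untested is meant among the compounds shown, and "the series" means these compounds.

Three compounds share one core and differ only in the group attached to it. Compound 1 `Cc1nc(N2CCN(C3CCOCC3)CC2)nc2ccc(NC(=O)COc3ccc(Cl)cc3)cc12` carries an oxan-4-yl piperazine and in an assay on CHO-K1 cells for displacement of a labelled ligand from melanin-concentrating hormone receptor 1 (Homo sapiens), with a stated time of 2 h (a higher number here means a weaker inhibitor, a lower number a stronger inhibitor), compound 1 gives 45 nM. Compound 2 `CCN1CCN(c2nc(C)c3cc(NC(=O)COc4ccc(Cl)cc4)ccc3n2)CC1` carries an ethyl piperazine; in this assay compound 2 gives 690 nM. Compound 3 `Cc1nc(N2CCC(O)CC2)nc2ccc(NC(=O)COc3ccc(Cl)cc3)cc12` carries a 4-hydroxypiperidin-1-yl group and in this assay compound 3 gives 150 nM, which places compound 3 second of the three, stronger than compound 2 and weaker than compound 1, both gaps beyond the scatter. The new compound 4 `Cc1nc(N2CCN(CC(C)(C)C)CC2)nc2ccc(NC(=O)COc3ccc(Cl)cc3)cc12` arises from compound 3 through (4-neopentylpiperazin-1-yl in place of 4-hydroxypiperidin-1-yl on an aromatic carbon). Among the measured compounds shown here, two measured steps bear on this: a 15-fold higher number from compound 1 to compound 2 (1.19 log units; beyond the scatter) and a 4.6-fold lower number from compound 2 to compound 3 (0.66 log units; beyond the scatter). Compound 4 resembles compound 2 in bearing an alkyl group on the piperazine nitrogen, yet a larger one, so compound 4 is expected to land closer to compound 3 than compound 2 did, giving an expected 1.7-fold higher number from compound 3 to compound 4 (0.22 log units; within the scatter). The estimate for compound 4 in this assay is 250 nM, ranging from 60 nM to 1000 nM.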

Compound 4, half-maximal inhibitory concentration: 782 nM
Estimate against measurement, compound 4: 3.1-fold (0.50 log units) below; the measured number falls inside the stated range.
By their numbers in this assay, from the lowest: compound 1; then compound 3; then compounds 2 and 4 (each within the scatter of the next).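

In this assay, a neopentyl group on the piperazine nitrogen reads the same as the ethyl group within the scatter (a 1.1-fold higher number from compound 2 to compound 4 (0.05 log units; within the scatter)), so the larger alkyl group does not recover what the ethyl group gave up. The neopentyl compound also stays well behind both oxygen-bearing compounds (a 5.2-fold higher number from compound 3 to compound 4 (0.72 log units; beyond the scatter); a 17-fold higher number from compound 1 to compound 4 (1.24 log units; beyond the scatter)), and among these four compounds the two whose group contains oxygen have the lower numbers, with no compound going against this. Nothing available explains this difference between the groups.

Going by these compounds, it remains open whether the oxygen itself sets compound 1 and compound 3 apart, or whether the rest of each group also contributes. A 2-hydroxyethyl or 2-methoxyethyl chain on the piperazine nitrogen would put oxygen on an open chain and help separate these readings.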